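The source may report more compounds than this note shows. Statements on the series, on what has been measured and on what is new or still open speak of the compounds shown alone.

Of the compounds shown here, three sharing one core have been measured in a functional assay on CCRF-CEM cells (Homo sapiens) for inhibition, read by sulforhodamine B assay, with a stated time of 48 h, tested at 10 uM; on this read-out higher numbers stand for a weaker effect at the one concentration tested and lower numbers for a stronger effect. Compound 1 `COc1cc(Cl)cc(-c2nn(-c3cccc(NC(=O)Nc4ccc(Cl)c(C(F)(F)F)c4)c3)cc2-c2ccncc2)c1` gives 1.88%. Compound 2 `COc1cc(Cl)cc(-c2nn(-c3cccc(NC(=O)Nc4ccc(Cl)c(Cl)c4)c3)cc2-c2ccncc2)c1` gives 5.73%. Compound 3 `COc1cc(Cl)cc(-c2nn(-c3cccc(NC(=O)Nc4cccc(C(F)(F)F)c4)c3)cc2-c2ccncc2)c1` gives 3.34%; its reading lies within the scatter of both others, as the steps of a number 1.5 percentage points higher from compound 1 to compound 3 (within the scatter) and a number 2.4 percentage points lower from compound 2 to compound 3 (within the scatter) show, and the step of a number 3.9 percentage points higher from compound 1 to compound 2 (within the scatter) lies within the scatter as well. Compound 4 `COc1cc(Cl)cc(-c2nn(-c3cccc(NC(=O)c4cccc(C(F)(F)F)c4)c3)cc2-c2ccncc2)c1` has not yet been measured. It differs from compound 3 by 3-(trifluoromethyl)phenyl in place of (3-(trifluoromethyl)phenyl)amino on a carbonyl carbon. Among the compounds with values here, none of the measured steps touches the carbonyl carbon; each exchanges groups elsewhere in the molecule, and each stayed within the scatter. Within the data shown here, no measured step therefore points to a direction, and compound 4 is expected to give 10%, somewhere between 1.5% and 45%. This estimate means a step of a number 6.7 percentage points higher from compound 3 to compound 4 (within the scatter).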

Compound 4, a percentage reported as activity, at one concentration (the size of the read-out at that concentration, not a potency): 42.3%
Compound 4: the middle estimate sits 32.3 percentage points below what was measured; the measured number falls inside the stated range.
By their numbers in this assay, from the lowest: compounds 1, 3 and 2 (each within the scatter of the next); then compound 4.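

The earlier exchanges of chloro and trifluoromethyl groups all stayed within the scatter, but this change on the carbonyl carbon has a large effect in this assay: a number 39 percentage points higher from compound 3 to compound 4 (beyond the scatter), and likewise a number 36.6 percentage points higher from compound 2 to compound 4 (beyond the scatter) and a number 40.4 percentage points higher from compound 1 to compound 4 (beyond the scatter). Since higher numbers mean a weaker effect, losing the amino nitrogen at this position weakens the effect at the one concentration tested. No available data explain why.

The compounds shown leave open whether the nitrogen itself or the hydrogen on it matters. A methylamino or a methylene link on the carbonyl carbon would help separate these two possibilities.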